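O-substituent variation on the shared core: 4-cyanobenzyl analogue

The compounds below may be only part of what the source reports. "The series", "measured", "known", "first", "only" and "open" are said of these compounds alone.

Measured so far in a functional assay on a cell-free system (plasma, Oryctolagus cuniculus) for inhibition, with stated times of 5 min, 1 min and 6 min; a higher number here means a weaker inhibitor, a lower number a stronger inhibitor:
compound 1 `CCOC(=O)c1c(C)nc(-c2cccc(C#N)c2)n1O` gives 17600 nM
compound 2 `CCOC(=O)COn1c(-c2cccc(C#N)c2)nc(C)c1C(=O)OCC` gives 6800 nM

Compound 1 carries the highest number of the two measured in this assay; its nearest neighbour is compound 2, reached by the step of a 2.6-fold lower number from compound 1 to compound 2 (0.41 log units; beyond the scatter), a replacement of the hydrogen on the ring oxygen by (ethoxycarbonyl)methyl.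

Compound 3 `CCOC(=O)c1c(C)nc(-c2cccc(C#N)c2)n1OCc1ccc(C#N)cc1` is not yet measured in this assay. Relative to compound 1 it shows (4-cyanobenzyl in place of hydrogen on an oxygen on an aromatic ring). Among the compounds with values here, the one measured step that bears on this change is the step from compound 1 to compound 2, which substitutes the same hydrogen on the same oxygen and gives a modest improvement beyond the scatter. A substituent of a different kind enters here, so the size is uncertain, but the direction is taken from that step. For compound 3 a lower number than for compound 1 is expected, the estimated step being a 3.9-fold lower number from compound 1 to compound 3 (0.59 log units; beyond the scatter). Compound 3 is therefore estimated at 4500 nM, with a range from 1500 nM to 13000 nM.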

Compound 3, half-maximal inhibitory concentration: 4240 nM
Compound 3: the middle estimate sits 1.1-fold (0.03 log units) above what was measured, and the stated range covers the measured number.
By their numbers in this assay, from the lowest: compounds 3 and 2 (each within the scatter of the next); then compound 1.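

In this assay, a second substituent of a different kind on the oxygen on an aromatic ring also lowers the number: 4-cyanobenzyl in place of hydrogen gives a 4.2-fold lower number from compound 1 to compound 3 (0.62 log units; beyond the scatter), so the direction seen with (ethoxycarbonyl)methyl is no longer tied to that one group. Exchanging ethoxycarbonyl for 4-cyanophenyl on the saturated chain carbon gives a 1.6-fold lower number from compound 2 to compound 3 (0.21 log units; within the scatter), so this assay does not separate the two substituents, and the gain over hydrogen is shared by two quite different groups. No supporting data bear on the origin of these steps.

Still open, going by these compounds, is whether any carbon substituent on this oxygen would do the same, which a plain methyl or a longer alkyl chain would test. Also open, on these data alone, is what a carboxylic acid in place of the ethoxycarbonyl, or an unsubstituted benzyl in place of the 4-cyanobenzyl, would give.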